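The compounds below may be only part of what the source reports. "The series", "measured", "known", "first", "only" and "open" are said of these compounds alone.

In a functional assay on A549 cells (Homo sapiens) for antiproliferative activity, read by MTT assay, with a stated time of 72 h (on this read-out higher numbers stand for weaker inhibition of growth and lower numbers for stronger inhibition of growth), compound 3 `Cc1ccc2nc(-c3ccc([N+](=O)[O-])cc3)cn2c1` gives > 100000 nM, which is a limit and not a number. Compound 1 `COc1cc(OC)n2cc(-c3ccc(N)cc3)nc2n1` gives > 100000 nM, also a limit. Compound 3 therefore stands at the limit of > 100000 nM in this assay, at which 2 of the 3 values shown sit. Among the compounds with values here, on the core of compound 1, compound 2 `COc1cc(OC)n2cc(-c3ccc(N(Cc4ccccc4)Cc4ccccc4)cc3)nc2n1` gives 7000 nM, the only reading that is a number. Compound 4 `Cc1ccc2nc(-c3ccc(NCc4ccccc4)cc3)cn2c1` has benzylamino in place of nitro on an aromatic carbon, para to a large group (benzylamino in place of nitro on an aromatic carbon). Compound 2, at 7000 nM, also carries benzyl groups on its amino nitrogen, so a clear move towards stronger inhibition of growth is expected. The expected step is an at least 5.0-fold lower number from compound 3 to compound 4 (0.69 log units; beyond the scatter). For compound 4 the estimated value is 20000 nM, with an expected range of 5000 nM to 100000 nM.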

Compound 4, concentration for 50% growth inhibition: 56100 nM
The estimate for compound 4 lay 2.8-fold (0.45 log units) below the measured number; low and high end bracket the measured number.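

In this assay, benzylamino in place of nitro on an aromatic carbon, para to a large group, gives an at least 1.7-fold lower number from compound 3 to compound 4 (0.25 log units; that floor lies within the scatter). Compound 3 gives > 100000 nM, which is a limit. The size of this change therefore remains only a floor, because the nitro end of the step sits at that limit: the limit of > 100000 nM in this assay, at which 2 of the 4 values shown sit.

Going by these compounds, it remains open whether a longer chain such as phenethylamino, or a carboxylic acid, in this place would give a lower number. On these data alone, how much of the step belongs to the benzyl ring and how much to the amino nitrogen also remains open.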